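Trimming the acid side chain by one carbon

A few compounds are considered here, and "the series" means these few. Any claim that something is new, unique, unknown or untested is made for them only; others in the source may bear on it.

Among the measured compounds shown here, in an ADME assay on cells (Hepatocyte, Mus musculus) for metabolic stability, read by LC-MS, with a stated time of 180 min, tested at 1 uM (on this read-out higher numbers stand for fast clearance and lower numbers for slow clearance), compound 2 (`CCC(C(=O)O)c1nn(Cc2cn3cc(OCC4CC4)c(Cl)cc3n2)c2ccccc2c1=O`) gives 155 mL/min/kg and holds the higher of the two numbers measured so far. For the measured compounds named here, the only other measured compound, compound 1 (`CC(C(=O)O)c1nn(Cc2cn3cc(OCC4CC4)c(Cl)cc3n2)c2ccccc2c1=O`), gives 76.7 mL/min/kg on the same read-out.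

Compound 3 (`C[C@H](C(=O)O)c1nn(Cc2cn3cc(OCC4CC4)c(Cl)cc3n2)c2ccccc2c1=O`) keeps the shared core and differs from compound 2 by 1-carboxyethyl in place of 1-carboxypropyl on an aromatic carbon and so has 1-carboxyethyl in place of 1-carboxypropyl on an aromatic carbon. This is the group compound 1 carries, but here with one defined stereocentre.

Going by the values given here, one measured step bears on the change. It is a 2.0-fold higher number from compound 1 to compound 2 (0.31 log units; beyond the scatter) and is modest but beyond the scatter, and compound 3 goes back the other way along it. The data hold no comparison of a defined stereocentre with an undefined one, so compound 3 could fall on either side of compound 1.

A modest fall of similar size is therefore expected in this assay for this change. The estimated step is a 1.9-fold lower number from compound 2 to compound 3 (0.29 log units; within the scatter) in all. Compound 3 is expected at about 80 mL/min/kg with an estimated range from 40 mL/min/kg to 150 mL/min/kg on this read-out.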

Compound 3, clearance in the Hepatocyte assay: 33.3 mL/min/kg
For compound 3 the middle estimate is 2.4-fold (0.38 log units) above the measured one, and the stated range ends above it.
By their numbers in the Hepatocyte assay, from the lowest: compound 3; then compound 1; then compound 2.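

In the Hepatocyte assay, going from 1-carboxypropyl to 1-carboxyethyl with a defined stereocentre gives a 4.7-fold lower number from compound 2 to compound 3 (0.67 log units; beyond the scatter), a larger fall than the earlier step alone could suggest, which was a 2.0-fold higher number from compound 1 to compound 2 (0.31 log units; beyond the scatter). Among the compounds shown here, with atoms and bonds unchanged, the step of a 2.3-fold lower number from compound 1 to compound 3 (0.36 log units; beyond the scatter) is the first sign in these compounds that the drawn configuration at this saturated chain carbon goes with the clearance number, and the one difference behind it is this: the fact that one of compounds 1 and 3 is drawn with a defined configuration and the other without, at the place where they differ. In a physicochemical assay for lipophilicity, at pH 7.4 (on this read-out higher numbers stand for higher lipophilicity and lower numbers for lower lipophilicity), compound 2 gives 2.71 and compound 3 gives 2.39. The shorter chain also comes with a lower distribution coefficient in the physicochemical assay, which may go with the fall in clearance: the measured distribution coefficient of compound 2, 2.71, and of compound 3, 2.39, a number 0.32 log units lower (beyond the scatter).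

The compounds shown leave open how the opposite configuration at this carbon would read, and how much of the fall from compound 2 belongs to the shorter chain and how much to the defined stereocentre, as compound 2 is itself drawn without a configuration. They also leave open whether an amide or a tetrazole in place of the carboxylic acid would hold the clearance number near that of compound 3.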